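Ring methyl across two cores in an antagonist assay

The compounds below may be only part of what the source reports. "The series", "measured", "known", "first", "only" and "open" are said of these compounds alone.

Compound 1 `CC(C#CCn1ccnc1)N1CCCC1=O` and compound 2 `Cc1cncn1CC#CC(C)N1CCCC1=O` share one core; in a functional assay on the whole organism for antagonist activity, with Mus musculus as the target (on this read-out higher numbers stand for an effect only at larger amounts of compound and lower numbers for an effect already at smaller amounts), compound 1 gives 45 mg/kg and compound 2 gives 25.4 mg/kg. The change methyl in place of hydrogen on an aromatic carbon made a 1.8-fold lower number from compound 1 to compound 2 (0.25 log units; within the scatter). Compound 3 `CC(=O)NCC#CCn1ccnc1` rests on a second core; the difference between the two cores is not broken down here. In this assay compound 3 gives only a limit, > 100 mg/kg, which the limit of > 100 mg/kg in this assay, at which 1 of the 3 values shown sits, records. Compound 4 `CC(=O)NCC#CCn1cncc1C` is compound 3 with methyl in place of hydrogen on an aromatic carbon. Around the place the ring atom is here described as bearing a group of 8 heavy atoms rather than a large group, so this is the same kind of change as before. The step from compound 3 to compound 4 is expected to be a step that the limit leaves unreadable from compound 3 to compound 4 in this assay, resting on the earlier 1.8-fold lower number from compound 1 to compound 2 (0.25 log units; within the scatter). Compound 4 is estimated at 120 mg/kg in this assay.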

Compound 4, dose for half-maximal effect: > 100 mg/kg
Compound 4 was reported as a limit; the forecaster's own chance of this, stated with the estimate: 65%; the middle value does not contradict the limit.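

No step can be read from compound 3 to compound 4 in this assay, since each is reported only as a limit: the limit of > 100 mg/kg in this assay, at which 2 of the 4 values shown sit.

Left open is what methyl in place of hydrogen on an aromatic carbon does to the read-out on the core of compound 3.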